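Replacing ethyl on the ring amine of compound 3

The source may report more compounds than this note shows. Statements on the series, on what has been measured and on what is new or still open speak of the compounds shown alone.

Measured in an in vitro ADME assay on microsomes from liver (Mus musculus) for pharmacokinetics, read by LC-MS, with a stated time of 10 min, tested at 1 uM; on this read-out higher numbers stand for fast clearance and lower numbers for slow clearance:
- compound 1 `CN1C[C@H](C(=O)Nc2ccc(Cl)c(Cl)c2)[C@@H](c2ccc(/C=C/C(=O)Nc3ccccc3N)cc2)C1`: 36 mL/min/kg
- compound 2 `CN1C[C@H](C(=O)Nc2ccccn2)[C@@H](c2ccc(/C=C/C(=O)Nc3ccccc3N)cc2)C1`: 40 mL/min/kg
- compound 3 `CCN1C[C@H](C(=O)Nc2ccc(Cl)cc2)[C@@H](c2ccc(/C=C/C(=O)Nc3ccccc3N)cc2)C1`: 35 mL/min/kg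

Compound 3, at 35 mL/min/kg, lies within the scatter of both other compounds, so the three values form a single level. The unmeasured compound 4 `CCN(CC)C(=O)N1C[C@H](C(=O)Nc2ccc(Cl)cc2)[C@@H](c2ccc(/C=C/C(=O)Nc3ccccc3N)cc2)C1` differs from compound 3 in one place: diethylcarbamoyl in place of ethyl on an amine nitrogen in a ring. Going by the values given here, the only measured single-place step is a 1.1-fold higher number from compound 1 to compound 2 (0.05 log units; within the scatter), and it stays within the scatter. That step concerns an amide-type nitrogen, however, and not the amine nitrogen in the ring. Among the compounds with values here, no measured step isolates a change at the ring amine, so the data give no firm direction. A shift beyond the scatter in this assay is therefore not expected, although the range has to stay wide for an untested change. The expected step is a 1.2-fold higher number from compound 3 to compound 4 (0.08 log units; within the scatter). For compound 4 the estimated clearance is 42 mL/min/kg, with an expected range of 20 mL/min/kg to 75 mL/min/kg.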

Compound 4, clearance: 83 mL/min/kg
The estimate for compound 4 lay 2.0-fold (0.30 log units) below the measured number, outside the stated range (above it).
By their numbers in this assay, from the lowest: compounds 3, 1 and 2 (each within the scatter of the next); then compound 4.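

In this assay, going by these compounds alone, the change from ethyl to diethylcarbamoyl on the amine nitrogen in the ring gives a 2.4-fold higher number from compound 3 to compound 4 (0.38 log units; beyond the scatter) and is the first single-place step to pass the scatter. The earlier step of a 1.1-fold higher number from compound 1 to compound 2 (0.05 log units; within the scatter) stayed within the scatter, but it lay on an amide-type nitrogen, so only now is clearance shown to respond to a change at the ring amine. Nothing measured here accounts for the rise.

Going by these compounds, it remains open whether the rise follows the carbonyl of diethylcarbamoyl or its two ethyl groups, which an acetyl or a dimethylcarbamoyl group on this nitrogen would help separate. Also open, on these data alone, is whether the same change carries over to compounds with 3,4-dichlorophenyl or pyridin-2-yl on the amide-type nitrogen.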